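The compounds below may be only part of what the source reports. "The series", "measured", "known", "first", "only" and "open" are said of these compounds alone.

Measured compounds:
Compound 1 `CC(C)c1ccc(Nc2ccc3c(OCCCN4CCN(C)CC4)cccc3n2)cc1` – 7280 nM
Compound 2 `CN1CCN(CCCOc2cccc3nc(Nc4cccc(Cl)c4)ccc23)CC1` – 1850 nM
Compound 3 `CN1CCN(CCCOc2cccc3nc(Nc4cc(Cl)cc(Cl)c4)ccc23)CC1` – 1670 nM

In a functional assay on RXF 393 cells (Homo sapiens) for inhibition, read by sulforhodamine B assay, with a stated time of 48 h (a higher number here means a weaker inhibitor of growth, a lower number a stronger inhibitor of growth), compound 3 has the lowest number of the three, though its gap to compound 2 is within the scatter, and only compound 1 sits clearly higher. Compound 4 `CN1CCN(CCCOc2cccc3nc(Nc4ccc(Cl)c(F)c4)ccc23)CC1` is the next step: 4-chloro-3-fluorophenyl in place of 3,5-dichlorophenyl on a nitrogen on an aromatic ring. Two earlier steps bear on it. Swapping the isopropyl group for a chlorinated ring gave a 3.9-fold lower number from compound 1 to compound 2 (0.59 log units; beyond the scatter) and a 4.4-fold lower number from compound 1 to compound 3 (0.64 log units; beyond the scatter), while adding a second chloro gave a 1.1-fold lower number from compound 2 to compound 3 (0.04 log units; within the scatter). Compound 4 keeps a halogenated ring, so the expected step is a 1.1-fold higher number from compound 3 to compound 4 (0.06 log units; within the scatter), nothing beyond the scatter. Compound 4 is therefore estimated at 1900 nM, within 850 nM to 4200 nM.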

Compound 4, concentration for 50% growth inhibition: 1960 nM
For compound 4 the middle estimate is 1.0-fold (0.01 log units) below the measured one, within the range that was stated.
By their numbers in this assay, from the lowest: compounds 3, 2 and 4 (each within the scatter of the next); then compound 1.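

Placing 4-chloro-3-fluorophenyl where 3,5-dichlorophenyl stood makes no real difference in this assay (a 1.2-fold higher number from compound 3 to compound 4 (0.07 log units; within the scatter)), and the same holds against 3-chlorophenyl (a 1.1-fold higher number from compound 2 to compound 4 (0.03 log units; within the scatter)). A ring carrying fluorine as well as chlorine therefore stays level with the two chlorinated rings and still separates from 4-isopropylphenyl (a 3.7-fold lower number from compound 1 to compound 4 (0.57 log units; beyond the scatter)). No measurement shown explains this result.

As far as these compounds go, whether a methoxy group or a nitrile on this ring would stay level with the halogenated rings remains open. Also open, from the compounds shown here alone, is whether plain phenyl would match them or compound 1.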